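Solubility of a quinoline-like series: a cyanobenzyl variant

The compounds below may be only part of what the source reports. "The series", "measured", "known", "first", "only" and "open" are said of these compounds alone.

Measured so far:
compound 1 `Fc1ccc(-c2ccc3c(NCCCNCc4ccco4)ccnc3c2)cc1`: 32000 nM
compound 2 `COc1ccc(F)cc1CNCCCNc1ccnc2cc(Oc3ccc(F)cc3)ccc12`: 14500 nM
compound 3 `COc1ccc(F)cc1CNCCCNc1ccnc2cc(-c3ccc(F)cc3)ccc12`: 32000 nM

In a physicochemical assay for solubility, with a stated time of 18 h, at pH 7.4 (a lower number here means a less soluble compound, a higher number a more soluble compound), compound 1 stands level with compound 3, the two together the highest of the three numbers, while compound 2 sits lower, as a 2.2-fold higher number from compound 2 to compound 3 (0.34 log units; beyond the scatter) shows. Compound 4 `N#Cc1ccc(Cc2ccc3c(NCCCNCc4ccco4)ccnc3c2)cc1` differs from compound 1 by 4-cyanobenzyl in place of 4-fluorophenyl on an aromatic carbon. Among the measured compounds shown here, no measured step touches this kind of change; no change at the digits printed from compound 1 to compound 3 (within the scatter) concerns the other end of the molecule, and a 2.2-fold higher number from compound 2 to compound 3 (0.34 log units; beyond the scatter) concerns a different group at the same place. For the measured compounds named here, the only guide is that changes here have stayed modest, so compound 4 is expected to stay near compound 1, with a 1.1-fold lower number from compound 1 to compound 4 (0.06 log units; within the scatter) as the expected step and 28000 nM as the estimate, between 11000 nM and 70000 nM.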

Compound 4, solubility: 4200 nM
Estimate against measurement, compound 4: 6.7-fold (0.82 log units) above; measured number below the stated range.
By their numbers in this assay, from the lowest: compound 4; then compound 2; then compounds 1 and 3 (each within the scatter of the next).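

In this assay, this aromatic carbon proves sensitive to the group it carries: with 4-cyanobenzyl in place of 4-fluorophenyl, there is a 7.6-fold lower number from compound 1 to compound 4 (0.88 log units; beyond the scatter). The earlier change at this place was smaller, with a 2.2-fold higher number from compound 2 to compound 3 (0.34 log units; beyond the scatter). Nothing measured here gives a reason for the larger step.

From the compounds shown here alone, the new group differs from 4-fluorophenyl in both its benzyl link and its nitrile, so which of these matters remains open. A 4-fluorobenzyl or a 4-cyanophenyl group at this place would separate the two.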